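Swapping Hydroxy for Piperidin-1-yl on the Chain

This account rests on a few compounds, and the source may have more. Where it says the series, first, only, none or still open, it means among the compounds named here.

Values in a functional assay on HL-60 cells (Homo sapiens) for antiproliferative activity, read by MTT assay, with a stated time of 48 h; a higher number here means a weaker inhibitor, a lower number a stronger inhibitor:
- compound 1 `CCN(CC)CCn1c(N)c(-c2nc3ccccc3[nH]2)c2nc(C#N)c(C#N)nc21`: 1880 nM
- compound 2 `N#Cc1nc2c(-c3nc4ccccc4[nH]3)c(N)n(CCCO)c2nc1C#N`: > 50000 nM

Compound 2 stands at the limit of > 50000 nM in this assay, at which 1 of the 2 values shown sits, so its value is a limit of the assay and not a number. Its true position in this assay is therefore open on one side.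

The next compound, compound 3 `N#Cc1nc2c(-c3nc4ccccc4[nH]3)c(N)n(CCCN3CCCCC3)c2nc1C#N`, has not yet been measured. It differs from compound 2 by piperidin-1-yl in place of hydroxy on a saturated chain carbon, three bonds along the chain from an aromatic nitrogen. Put another way, 3-hydroxypropyl gives way to 3-(piperidin-1-yl)propyl, with piperidin-1-yl in place of hydroxy on a saturated chain carbon.

Among the compounds with values here, only one measured step bears on this change: an at least 26-fold higher number from compound 1 to compound 2 (1.42 log units; beyond the scatter). That step is large and beyond the scatter, and it ends at a hydroxy-bearing chain, as compound 3 starts from one. The present change runs the opposite way, from hydroxy to a nitrogen-linked group, so a large move towards a lower number is expected. The expected step is an at least 20-fold lower number from compound 2 to compound 3 (1.30 log units; beyond the scatter). This rests on a single pair, so the estimate stays broad and is anchored on compound 1 at 1880 nM. For compound 3 the expected value is 2500 nM, with an estimated range of 700 nM to 10000 nM.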

Compound 3, half-maximal inhibitory concentration: 1680 nM
Compound 3: middle estimate off by 1.5-fold (0.17 log units), on the high side; the measured number falls inside the stated range.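

In this assay, 3-(piperidin-1-yl)propyl in place of 3-hydroxypropyl brings a large change, an at least 29-fold lower number from compound 2 to compound 3 (1.47 log units; beyond the scatter), so the large step seen earlier on leaving the diethylamino chain for a hydroxy-bearing chain now has a counterpart in the opposite direction, on a chain of a different length and with a ring in the entering group. Compound 2 stands at a limit of the assay and not at a number, so the true size of this step stays open on one side: the limit of > 50000 nM in this assay, at which 1 of the 3 values shown sits. The two nitrogen-bearing chains, meanwhile, cannot be told apart in this assay, with a 1.1-fold lower number from compound 1 to compound 3 (0.05 log units; within the scatter), so across the three compounds shown, the diethylamino and piperidin-1-yl chains sit together and the hydroxy-bearing chain alone stands apart, with no compound going against this.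

What the compounds leave open is whether the chain nitrogen itself carries this difference, which a morpholine ring, a primary amine or a carboxylic acid at the end of the same chain would help to separate. They also leave open how far the value depends on chain length, as a longer chain bearing piperidin-1-yl does not appear among them.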